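Isobutyl for isopropyl, second pairing in the series

This account rests on a few compounds, and the source may have more. Where it says the series, first, only, none or still open, it means among the compounds named here.

Three compounds of the series share one core. In an assay (strain Wistar) for inhibition of Hormone-sensitive lipase (Rattus norvegicus), read by spectrophotometry (on this read-out lower numbers stand for stronger inhibition and higher numbers for weaker inhibition), compound 1 `Cc1c(C(C)C)c(=O)on1C(=O)N1CCCCC1` gives 2 nM. Compound 2 `Cc1c(CC(C)C)c(=O)on1C(=O)N1CCCCC1` gives 5 nM in this assay, and compound 3 `Cc1c(C(C)C)c(=O)on1C(=O)N1CCC(c2ccccc2)CC1` gives 12 nM. Compound 3 thus stands with the highest number of the three; its nearest neighbour is compound 2 and its furthest is compound 1, both gaps beyond the scatter. Two single-point changes have been measured: a 6.0-fold higher number from compound 1 to compound 3 (0.78 log units; beyond the scatter), and a 2.5-fold higher number from compound 1 to compound 2 (0.40 log units; beyond the scatter).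

Compound 4 `Cc1c(CC(C)C)c(=O)on1C(=O)N1CCC(c2ccccc2)CC1` differs from compound 3 by isobutyl in place of isopropyl on an aromatic carbon. This repeats the change already measured as a 2.5-fold higher number from compound 1 to compound 2 (0.40 log units; beyond the scatter), now on the core that carries the phenyl group. Because that step a 2.5-fold higher number from compound 1 to compound 2 (0.40 log units; beyond the scatter) was modest and beyond the scatter, a step of similar size and the same direction is expected for compound 4: a 2.5-fold higher number from compound 3 to compound 4 (0.40 log units; beyond the scatter). Compound 4 is therefore expected to give about 30 nM in this assay, with a likely range from 12 nM to 75 nM.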

Compound 4, half-maximal inhibitory concentration: 10 nM
The estimate for compound 4 lay 3.0-fold (0.48 log units) above the measured number; measured number outside the range, below it.
By their numbers in this assay, from the lowest: compound 1; then compounds 2, 4 and 3 (each within the scatter of the next, the first and the last beyond it).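

On the core that carries the phenyl group, isobutyl in place of isopropyl on an aromatic carbon gives a 1.2-fold lower number from compound 3 to compound 4 (0.08 log units; within the scatter) in this assay, so the step seen on the core of compound 1 is not a fixed increment for this position. The change therefore reads differently on the two cores: the same change on two cores in this assay, a 2.5-fold higher number (0.40 log units; beyond the scatter) from compound 1 to compound 2 and a 1.2-fold lower number (0.08 log units; within the scatter) from compound 3 to compound 4, 3.0-fold (0.48 log units) apart, beyond the scatter of two such steps. Read the other way, phenyl in place of hydrogen on a saturated ring carbon gives a 2.0-fold higher number from compound 2 to compound 4 (0.30 log units; within the scatter) with isobutyl on the aromatic carbon, so the two sites do not add independently in these four compounds: the same change on two cores in this assay, a 6.0-fold higher number (0.78 log units; beyond the scatter) from compound 1 to compound 3 and a 2.0-fold higher number (0.30 log units; within the scatter) from compound 2 to compound 4, 3.0-fold (0.48 log units) apart, beyond the scatter of two such steps.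

The compounds shown hold only isopropyl and isobutyl at this position, so it remains open whether a longer chain such as n-pentyl or a cyclopropyl group would follow either core. Also open, going by these compounds, is whether the same dependence appears with an amine or a carboxylic acid in place of the phenyl group.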